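This account rests on a few compounds, and the source may have more. Where it says the series, first, only, none or still open, it means among the compounds named here.

Measured in a toxicity assay on NIH3T3 cells (Mus musculus) for cytotoxicity, read by resazurin assay; a higher number here means that more compound is needed for the effect, a lower number that less compound is needed:
Compound 1 `COC(=O)c1ccc(NCc2cncn2Cc2ccccc2N)cc1-c1ccccc1`: 25000 nM
Compound 2 `COC(=O)c1ccc(NCc2cncn2Cc2cccc(F)c2)cc1-c1ccccc1`: > 1000 nM (a limit)
Compound 3 `COC(=O)c1ccc(NCc2cncn2Cc2ccc(-c3ccccc3)cc2)cc1-c1ccccc1`: > 1000 nM (a limit)

In this assay compound 3 gives > 1000 nM, which is a limit and not a number. Compound 2 gives > 1000 nM, also a limit. Among the measured compounds shown here, the only true number is compound 1 at 25000 nM. The position of compound 3 therefore rests on this: the limit of > 1000 nM in this assay, at which 2 of the 3 values shown sit.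

Compound 4 `COC(=O)c1ccc(NCc2cncn2Cc2ccc(Br)cc2)cc1-c1ccccc1` carries bromo in place of phenyl on an aromatic carbon, read one bond further out as 4-phenylphenyl to 4-bromophenyl: bromo in place of phenyl on an aromatic carbon.

All three measured steps touch this same group, but none gives a size: a step that the limit leaves unreadable from compound 1 to compound 2, a step that the limit leaves unreadable from compound 1 to compound 3 and a step that the two limits leave unreadable from compound 2 to compound 3. No size or direction can be carried over from them, so no particular shift is expected in this assay, and another limit is the likeliest result. The expected step is a step that the limit leaves unreadable from compound 3 to compound 4. Compound 4 is estimated at 8000 nM, with an expected range from 1500 nM to 40000 nM.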

Compound 4, half-maximal effective concentration: > 10000 nM
Compound 4 ended at the assay's limit; the forecaster's own chance of this, stated with the estimate: 65%; middle value at least 1.2-fold (0.09 log units) away from the limit.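

In this assay compound 4 gives > 10000 nM, a limit and not a number. Among the compounds shown here, no step linking compound 4 to compound 1, compound 2 or compound 3 can be read. The compounds shown leave open whether compound 2, compound 3 and compound 4 differ from compound 1 or from one another.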